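Shorter Chain on the Ring Nitrogen: Compound 4 Expected

This account rests on a few compounds, and the source may have more. Where it says the series, first, only, none or still open, it means among the compounds named here.

The measured compounds:
Compound 1, `O=C(NO)c1ccc(-c2cn([C@H]3C[C@@H](C(=O)O)N(Cc4ccccc4)C3)nn2)cc1`, in an assay on Sf9 cells for inhibition of histone deacetylase 11 (Homo sapiens), read by fluorescence, tested at 0.5 uM (a lower number here means less inhibition, a higher number more inhibition at the concentration tested (going by the name of the read-out)), gives < 10%, which is a limit of the assay and not a number.
Compound 2, `O=C(NO)c1cccc(-c2cn([C@H]3C[C@@H](C(=O)O)N(CCCc4ccccc4)C3)nn2)c1`, gives in this assay < 10%, likewise a limit.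
Compound 3, `O=C(/C=C/c1cn([C@H]2C[C@@H](C(=O)O)N(CCCc3ccccc3)C2)nn1)NO`, gives in this assay 29%.

Compound 2 thus stands at the limit of the assay, where two of the three values sit (the limit of < 10% in this assay, at which 2 of the 3 values shown sit). Within the data shown here, only one step within the set is known: a number at least 19 percentage points higher from compound 2 to compound 3 (beyond the scatter), which alters the group that carries the hydroxycarbamoyl and leaves the amine substituent untouched. Compound 4, `O=C(NO)c1cccc(-c2cn([C@H]3C[C@@H](C(=O)O)N(Cc4ccccc4)C3)nn2)c1`, differs from compound 2 by phenyl in place of phenethyl on a saturated chain carbon bound to an amine nitrogen in a ring. Among the measured compounds shown here, no measured step changes this part of the molecule, so the only guide is that compound 1, which carries the benzyl group, also sits at the limit. The step that the limit leaves unreadable from compound 2 to compound 4 is therefore expected to be none beyond the scatter. Compound 4 is estimated at 5%, between 0% and 15%, and is expected most likely to be reported as a limit.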

Compound 4, a percentage reported as inhibition, at one concentration (the size of the read-out at that concentration, not a potency): 14%
Estimate against measurement, compound 4: 9 percentage points below; the range from low to high includes it.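

In this assay compound 4 gives 14%, the first number rather than a limit among the compounds shown that carry a hydroxycarbamoyl group on a phenyl ring. Benzyl in place of 3-phenylpropyl on the ring nitrogen gives a number at least 4 percentage points higher from compound 2 to compound 4 (that floor lies within the scatter), and 3-(hydroxycarbamoyl)phenyl in place of 4-(hydroxycarbamoyl)phenyl gives a number at least 4 percentage points higher from compound 1 to compound 4 (that floor lies within the scatter). Neither change is therefore shown to matter beyond the scatter, and the full size of neither step can be read because one end of each rests on a limit: the limit of < 10% in this assay, at which 2 of the 4 values shown sit.

The compounds shown leave open how benzyl behaves alongside the 2-(hydroxycarbamoyl)ethenyl group of compound 3. They also leave open whether a methyl ester in place of the carboxylic acid, or a longer chain such as 5-phenylpentyl on the ring nitrogen, would alter the read-out.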